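Methylating the Imidazole Nitrogen: From Compound 1 to Compound 4

This account rests on a few compounds, and the source may have more. Where it says the series, first, only, none or still open, it means among the compounds named here.

Three compounds sharing one core have been measured in an assay on isolated protein for displacement of a labelled ligand from Gonadotropin-releasing hormone receptor (Homo sapiens); on this read-out lower numbers stand for stronger inhibition and higher numbers for weaker inhibition:

compound 1 `Cc1nc(CN2CCN(c3cccc4[nH]c(-c5ccc(C(C)(C)C)cc5)nc34)CC2)c[nH]1` gives 7.5 nM
compound 2 `CCc1nc(C)c(CN2CCN(c3cccc4[nH]c(-c5ccc(C(C)(C)C)cc5)nc34)CC2)o1` gives 37 nM
compound 3 `CCCn1cnc(CN2CCN(c3cccc4[nH]c(-c5ccc(C(C)(C)C)cc5)nc34)CC2)c1C` gives 12 nM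

Compound 1 has the lowest number of the three. Its nearest neighbour is compound 3, with a 1.6-fold higher number from compound 1 to compound 3 (0.20 log units; within the scatter), a gap that does not exceed the usual scatter. The largest gap is to compound 2, with a 4.9-fold higher number from compound 1 to compound 2 (0.69 log units; beyond the scatter), a modest loss.

Compound 4 `CCc1nc(CN2CCN(c3cccc4[nH]c(-c5ccc(C(C)(C)C)cc5)nc34)CC2)cn1C` differs from compound 1 in one place: 2-ethyl-1-methyl-1H-imidazol-4-yl in place of 2-methyl-1H-imidazol-4-yl on a saturated chain carbon bound to an amine nitrogen in a ring. The group that enters carries no hydrogen-bond donor and has a methyl on the ring nitrogen and an ethyl instead of a methyl on the ring carbon.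

The step from compound 1 to compound 3 bears most directly on this change, since compound 3 also carries an alkyl on the ring nitrogen and no hydrogen-bond donor, and that step stayed within the scatter. The step to compound 2 shows that swapping the ring itself costs more, but compound 4 keeps the imidazole. The step expected for compound 4 is therefore a 1.6-fold higher number from compound 1 to compound 4 (0.20 log units; within the scatter), at most a small rise in this assay. Compound 4 is estimated at 12 nM, within a range from 5 nM to 30 nM.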

Compound 4, half-maximal inhibitory concentration: 18 nM
For compound 4 the middle estimate is 1.5-fold (0.18 log units) below the measured one; measured number inside the range.
By their numbers in this assay, from the lowest: compounds 1, 3 and 4 (each within the scatter of the next, the first and the last beyond it); then compound 2.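

In this assay the new result gives a 2.4-fold higher number from compound 1 to compound 4 (0.38 log units; beyond the scatter), so this position does respond to a change of the imidazole substituents, something the step from compound 1 to compound 3 alone did not reveal. The two imidazoles carrying an alkyl on the ring nitrogen and no hydrogen-bond donor sit close together, with a 1.5-fold higher number from compound 3 to compound 4 (0.18 log units; within the scatter), even though their alkyl groups differ in size and place. Among these compounds, the imidazole also keeps its edge over the 2-ethyl-4-methyl-1,3-oxazol-5-yl group, with a 2.1-fold lower number from compound 2 to compound 4 (0.31 log units; beyond the scatter), so that group now has a higher number than both of these imidazoles, not just the one in compound 3.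

The step from compound 1 to compound 4 changes two things at once, so the compounds shown cannot say whether the rise comes from the methyl on the ring nitrogen or from the ethyl replacing the methyl on the ring carbon, and an imidazole carrying only one of these changes would separate them, while a longer chain such as butyl on that ring carbon remains untested in this series. No measured evidence is at hand to explain any of these steps.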